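A few compounds are considered here, and "the series" means these few. Any claim that something is new, unique, unknown or untested is made for them only; others in the source may bear on it.

Measured compounds, with their numbers in a functional assay on LOX IMVI cells (Homo sapiens) for inhibition, read by sulforhodamine B assay, with a stated time of 48 h, tested at 10 uM; a lower number here means less inhibition, a higher number more inhibition at the concentration tested (going by the name of the read-out):
- compound 1 `Brc1cn2ccnc2c(-c2ccc3ncn(C4CCCCC4)c3c2)n1` gives 15.2%
- compound 2 `O=Cc1ccc(-c2cn3ccnc3c(-c3ccc4ncn(C5CCCCC5)c4c3)n2)cc1` gives 46.9%
- compound 3 `c1ccc2c(-c3cn4ccnc4c(-c4ccc5ncn(C6CCCCC6)c5c4)n3)cccc2c1` gives 7.43%

Compound 2 stands highest of the three; its nearest neighbour is compound 1, a number 31.7 percentage points higher from compound 1 to compound 2 (beyond the scatter), and its furthest is compound 3, a number 39.5 percentage points lower from compound 2 to compound 3 (beyond the scatter). Compound 1 and compound 3 sit within the scatter of each other, a number 7.8 percentage points lower from compound 1 to compound 3 (within the scatter).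

Compound 4 `Brc1ccc(-c2cn3ccnc3c(-c3ccc4ncn(C5CCCCC5)c4c3)n2)cc1` is the next step from compound 2: bromo in place of formyl on an aromatic carbon.

Going by the values given here, no measured step exchanges formyl for bromo on this phenyl ring, so nothing bears on the change directly. What the series does show is that the aryl group on the shared core matters: the 4-formylphenyl of compound 2 gives the highest number, while the naphthalen-1-yl of compound 3 gives a low one and the bare bromo of compound 1 likewise. A 4-bromophenyl keeps the aryl ring of compound 2 but drops the formyl; the expectation is a drop from compound 2, of uncertain size, with the low numbers of compound 1 and compound 3 as the floor.

The estimate for compound 4 is 25%, in the range 8% to 45%, which means an expected step of a number 21.9 percentage points lower from compound 2 to compound 4 (beyond the scatter).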

Compound 4, a percentage reported as inhibition, at one concentration (the size of the read-out at that concentration, not a potency): 30.7%
Beside the measured number, compound 4's estimate is 5.7 percentage points below it; the range from low to high includes it.
By their numbers in this assay, from the lowest: compounds 3 and 1 (each within the scatter of the next); then compound 4; then compound 2.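

In this assay, an aryl group at this place on the shared core does not by itself set the number: a number 15.5 percentage points higher from compound 1 to compound 4 (beyond the scatter), and this gain holds for the 4-bromophenyl group, whereas the naphthalen-1-yl group of compound 3 goes against any general aryl gain, since compound 3 stays within the scatter of compound 1. With the phenyl ring held constant, the group on that ring also counts, as a number 16.2 percentage points lower from compound 2 to compound 4 (beyond the scatter), so the high number of compound 2 belongs to the 4-formylphenyl group as a whole and not to the phenyl ring alone, while a number 23.3 percentage points higher from compound 3 to compound 4 (beyond the scatter) and places the 4-bromophenyl group clearly apart from the naphthalen-1-yl group. Nothing available explains why these groups differ in this cell assay.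

The compounds shown leave open where an unsubstituted phenyl would fall, and whether a nitrile, a carboxylic acid or an amine on the ring would stand nearer compound 2 or compound 4. Also open is whether the order of these compounds would hold at other concentrations, as each number comes from a single concentration and is not a potency.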